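Moving a Hydroxyl Group on a Weakly Active Pyridine Series

The compounds below may be only part of what the source reports. "The series", "measured", "known", "first", "only" and "open" are said of these compounds alone.

Compound 1 `Oc1ccccc1-c1cc(-c2cccs2)cc(-c2ccccc2O)n1` gives 0.2% in an assay on isolated protein for inhibition of DNA topoisomerase 1 (Homo sapiens), with a stated time of 30 min, tested at 20 uM; a lower number here means a weaker effect, a higher number a stronger effect of the compound at the concentration tested.
Compound 2 `Oc1cccc(-c2cc(-c3cccs3)cc(-c3ccccc3O)n2)c1` gives 1.5% in this assay.
Compound 3 `Oc1ccccc1-c1cc(-c2cccnc2)cc(-c2ccccc2O)n1` gives 0% in this assay.

All three numbers sit within the usual scatter of one another, so none of the three compounds can be ranked. Compound 1 and compound 3 share the same two 2-hydroxyphenyl arms and differ only in the core: pyridin-3-yl in place of thiophen-2-yl on an aromatic carbon. From compound 1 to compound 2 the change was 3-hydroxyphenyl in place of 2-hydroxyphenyl on an aromatic carbon, and the step was a number 1.3 percentage points higher from compound 1 to compound 2 (within the scatter). Compound 4 `Oc1cccc(-c2cc(-c3cccnc3)cc(-c3ccccc3O)n2)c1` relates to compound 3 in the same way: 3-hydroxyphenyl in place of 2-hydroxyphenyl on an aromatic carbon. The surroundings are not identical, since in compound 1 the place is meta to a thiophen-2-yl group while in compound 3 it is meta to a pyridin-3-yl group, so this is the same kind of change rather than the same change. From compound 3 to compound 4 a step of a number 1 percentage points higher from compound 3 to compound 4 (within the scatter) is expected, resting on the near-zero step seen in a number 1.3 percentage points higher from compound 1 to compound 2 (within the scatter) and on the low values of compound 1, compound 2 and compound 3. Compound 4 is therefore estimated at 1%, with a likely range from -5% to 8%.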

Compound 4, a percentage reported as inhibition, at one concentration (the size of the read-out at that concentration, not a potency): 0%
For compound 4 the middle estimate is 1 percentage points above the measured one; the measured number falls inside the stated range.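

In this assay, 3-hydroxyphenyl in place of 2-hydroxyphenyl gives no change at the digits printed from compound 3 to compound 4 (within the scatter), which matches the earlier step on the other core: the same change on two cores in this assay, a number 1.3 percentage points higher (within the scatter) from compound 1 to compound 2 and no change at the digits printed (within the scatter) from compound 3 to compound 4, 1.3 percentage points apart, within the scatter of two such steps. Pyridin-3-yl in place of thiophen-2-yl gives a number 1.5 percentage points lower from compound 2 to compound 4 (within the scatter), and this also agrees with its earlier step: the same change on two cores in this assay, a number 0.2 percentage points lower (within the scatter) from compound 1 to compound 3 and a number 1.5 percentage points lower (within the scatter) from compound 2 to compound 4, 1.3 percentage points apart, within the scatter of two such steps. Going by these compounds alone, all four compounds sit close to zero, so this agreement shows only that neither change produced a step beyond the scatter here, not that either change would carry over in the same way to a compound with a clearly larger read-out.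

The compounds shown leave open whether any change to the two arms can raise the read-out beyond the scatter. An amine or a carboxylic acid in place of the hydroxyl group would be one such change.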